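The source may report more compounds than this note shows. Statements on the series, on what has been measured and on what is new or still open speak of the compounds shown alone.

Measured so far in a functional assay on CCRF-CEM cells (Homo sapiens) for antiproliferative activity, read by trypan blue exclusion, with a stated time of 72 h; a higher number here means a weaker inhibitor, a lower number a stronger inhibitor: compound 1 `Cc1ccc(C(=O)NC(N)=O)cc1NC(=O)CCl` gives 3360 nM. Compound 3 `Cc1ccc(NC(=O)CI)cc1C(=O)NC(N)=O` gives 20000 nM. Compound 2 `NC(=O)NC(=O)c1ccc(F)c(NC(=O)CCl)c1` reaches only a limit of the assay, > 20000 nM, and not a number.

Compound 1 and compound 2 differ in one place: fluoro in place of methyl on an aromatic carbon. This gives an at least 5.9-fold higher number from compound 1 to compound 2 (0.77 log units; beyond the scatter), bounded only by the limit of > 20000 nM in this assay, at which 1 of the 3 values shown sits. How the core of compound 3 differs from the core of compound 1 is not broken down here. Compound 4 `NC(=O)NC(=O)c1cc(NC(=O)CI)ccc1F` is not yet measured; against compound 3 it shows (fluoro in place of methyl on an aromatic carbon). This is the same kind of change as before, though the surroundings differ: in compound 4 the fluoro sits ortho to a carbamoylcarbamoyl group and para to a ((iodomethyl)carbonyl)amino group, whereas in compound 2 it sits ortho to a ((chloromethyl)carbonyl)amino group and para to a carbamoylcarbamoyl group. Resting on an at least 5.9-fold higher number from compound 1 to compound 2 (0.77 log units; beyond the scatter), a step of a 2.0-fold higher number from compound 3 to compound 4 (0.30 log units; within the scatter) is expected, most likely ending at a limit. Compound 4 is therefore expected to give 40000 nM in this assay, within 12000 nM to 150000 nM.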

Compound 4, half-maximal inhibitory concentration: < 10 nM
Compound 4: no number, only a limit (the forecaster's own chance of this, stated with the estimate: 75%); middle value at least 4000-fold (3.60 log units) from the limit.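

Compound 4 gives < 10 nM, which is a limit of the assay and not a number. In this assay, the new step is an at least 2000-fold lower number from compound 3 to compound 4 (3.30 log units; beyond the scatter), so the effect of this change does not carry from one core to the other, not even in its direction: the same change on two cores in this assay, an at least 5.9-fold higher number (0.77 log units; beyond the scatter) from compound 1 to compound 2 and an at least 2000-fold lower number (3.30 log units; beyond the scatter) from compound 3 to compound 4, at least 11000-fold (4.07 log units) apart, beyond the scatter of two such steps. With one pair on each core, this does not show which difference between the cores decides the outcome, or how large either step truly is.

The compounds shown leave open whether the reversal follows the chloromethyl or iodomethyl group or the way the groups are arranged on the ring. Also open, going by these compounds, is how a different group in the same place, such as an amine or a methoxy group, would behave on either core.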